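The source may report more compounds than this note shows. Statements on the series, on what has been measured and on what is new or still open speak of the compounds shown alone.

Compounds measured in a functional assay (blood) for inhibition, with Homo sapiens as the target; a higher number here means a weaker inhibitor, a lower number a stronger inhibitor:
compound 1 `C/C(=N\OCCF)c1ccc(Sc2cc(F)cc(C3CCOCC3)c2)cc1` gives 40 nM;
compound 2 `C/C(=N\OCc1ccncc1)c1ccc(Sc2cc(F)cc(C3CCOCC3)c2)cc1` gives 300 nM;
compound 3 `COC(=O)c1cc(CO/N=C(\C)c2ccc(Sc3cc(F)cc(C4CCOCC4)c3)cc2)on1` gives 100 nM.

Compound 3 stands second highest of the three numbers. Its nearest neighbour is compound 1, reached by a 2.5-fold higher number from compound 1 to compound 3 (0.40 log units; beyond the scatter); its furthest is compound 2, reached by a 3.0-fold lower number from compound 2 to compound 3 (0.48 log units; beyond the scatter). The shared core is held constant throughout, and the series differs only in what sits on the saturated chain carbon bound to the oxygen.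

The next compound to consider is compound 4 `C/C(=N\O)c1ccc(Sc2cc(F)cc(C3CCOCC3)c2)cc1`. Its difference from compound 3 is hydrogen in place of (3-(methoxycarbonyl)-1,2-oxazol-5-yl)methyl on an oxygen, so the whole substituent on that oxygen is gone and a hydroxy group remains.

For the measured compounds named here, none of the measured steps removes this group outright; all three exchange one group on that carbon for another. They do show that this assay responds to what is placed there, with a 7.5-fold higher number from compound 1 to compound 2 (0.88 log units; beyond the scatter) the widest swing and a 2.5-fold higher number from compound 1 to compound 3 (0.40 log units; beyond the scatter) the narrowest. Taking compound 3 as the anchor, a modest step in either direction is plausible and the direction cannot be read from the three compounds alone.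

The working estimate for compound 4 in this assay is 150 nM, with a range of 40 nM to 600 nM, which means the step of a 1.5-fold higher number from compound 3 to compound 4 (0.18 log units; within the scatter) is expected.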

Compound 4, half-maximal inhibitory concentration: 80 nM
For compound 4 the middle estimate is 1.9-fold (0.27 log units) above the measured one, within the range that was stated.
By their numbers in this assay, from the lowest: compounds 1, 4 and 3 (each within the scatter of the next, the first and the last beyond it); then compound 2.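

Removing the whole (3-(methoxycarbonyl)-1,2-oxazol-5-yl)methyl group, with its 10 heavy atoms and its aromatic ring, leaves a hydroxy group on the oxygen bound to the double-bonded nitrogen, and in this assay this gives a 1.3-fold lower number from compound 3 to compound 4 (0.10 log units; within the scatter), so that group cannot be told apart from hydrogen here. The same holds for the 2-fluoroethyl group, with a 2.0-fold higher number from compound 1 to compound 4 (0.30 log units; within the scatter), which gives the series a hydrogen baseline that the earlier exchanges between substituents could not provide. Only the (pyridin-4-yl)methyl group stands apart from that baseline, with a 3.8-fold lower number from compound 2 to compound 4 (0.57 log units; beyond the scatter), so among the three groups a cost in this assay relative to the free hydroxy is seen for this one alone.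

As far as these compounds go, whether a carboxylic acid in place of the methyl ester on the 1,2-oxazole, a plain methyl on the oxygen or a 2-aminoethyl chain there would stay level with compound 4 or fall towards compound 2 remains open. Nothing available on these compounds explains why the steps come out this way.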